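Azole ring swap in the chain-linked biphenyl amide series

This account rests on a few compounds, and the source may have more. Where it says the series, first, only, none or still open, it means among the compounds named here.

Compound 1 `O=C(CCCCCCCc1cc(-c2cccnc2)on1)Nc1ccccc1-c1ccccc1` anchors the series: in an assay for inhibition of Nicotinamide phosphoribosyltransferase (Mus musculus), read by fluorescence and coupled enzyme assay, with a stated time of 1 h (on this read-out lower numbers stand for stronger inhibition and higher numbers for weaker inhibition), compound 1 gives 49.9 nM. Compound 2 `O=C(CCCCCCCc1cc(-c2cccnc2)[nH]n1)Nc1ccccc1-c1ccccc1` keeps the whole of compound 1 apart from its five-membered ring, but in this assay compound 2 gives "not determined" (no result reported); no number stands for it, so where compound 2 sits relative to compound 1 cannot be told. Compound 3 `O=C(CCCCCCCc1nnc(-c2cccnc2)[nH]1)Nc1ccccc1-c1ccccc1` is the next member and has not yet been measured in this assay. Compound 3 differs from compound 2 in one place: 5-(pyridin-3-yl)-4H-1,2,4-triazol-3-yl in place of 5-(pyridin-3-yl)-1H-pyrazol-3-yl on a saturated chain carbon, seven bonds along the chain from a carbonyl carbon. No measured pair in the series shows a change at that place, so the size of the step from compound 2 to compound 3 cannot be read from any shown values; only the value of compound 1 offers a reference for the series. From the compounds shown here alone, the expectation is that the step is modest, with a bias towards weaker inhibition, yet either direction remains open and a shift beyond the usual scatter cannot be ruled out. For compound 3 the estimate in this assay is 150 nM, with a range from 30 nM to 800 nM.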

Compound 3, half-maximal inhibitory concentration: 269 nM
Beside the measured number, compound 3's estimate is 1.8-fold (0.25 log units) below it, within the range that was stated.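

At this place, on a saturated chain carbon, seven bonds along the chain from a carbonyl carbon, the series now has its first readable step: in this assay, 5-(pyridin-3-yl)-4H-1,2,4-triazol-3-yl in place of 5-(pyridin-3-yl)-1,2-oxazol-3-yl gives a 5.4-fold higher number from compound 1 to compound 3 (0.73 log units; beyond the scatter). The five-membered ring is therefore not interchangeable on this read-out, since a change confined to that ring moves the number beyond the scatter, although the step is modest and compound 3 still gives a numerical result of 269 nM. No measurement bears on the reason for this step, and none is assigned here.

From the compounds shown here alone, the steps linking compound 2 to compound 1 and to compound 3 cannot be read, as compound 2 has no number, so the standing of the 5-(pyridin-3-yl)-1H-pyrazol-3-yl group remains unknown. Also open, going by these compounds, are how a 5-(pyridin-3-yl)-1,3,4-oxadiazol-2-yl group would compare at this place, and whether the step from compound 1 to compound 3 would keep its size on a longer chain.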